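Adding chloro to the phenyl of compound 1

The source may hold more compounds than are shown below. What is called first, only, known or untested is meant among the compounds shown, and "the series" means these compounds.

Going by the values given here, in a functional assay on KB cells (Homo sapiens) for antiproliferative activity, read by MTT assay, with a stated time of 48 h (a lower number here means a stronger inhibitor, a higher number a weaker inhibitor), compound 1 `Cn1cc(C2=C(c3nn(CCCN4CCCCC4)c4ncccc34)C(=O)N(c3ccccc3)C2=O)c2ccccc21` gives 5600 nM and is the only compound with a number so far. Compound 2 `Cn1cc(C2=C(c3nn(CCn4ccnc4)c4ncccc34)C(=O)N(c3ccccc3)C2=O)c2ccccc21` reads > 100000 nM in this assay and that value is a limit, not a number. Among the compounds with values here, the one measured step is large: an at least 17-fold higher number from compound 1 to compound 2 (1.25 log units; beyond the scatter) and it lies in the side chain, where 1H-imidazol-1-yl takes the place of (piperidin-1-yl)methyl. Compound 3 `Cn1cc(C2=C(c3nn(CCCN4CCCCC4)c4ncccc34)C(=O)N(c3ccc(Cl)cc3)C2=O)c2ccccc21` keeps the side chain of compound 1 and differs elsewhere: chloro in place of hydrogen on an aromatic carbon with phenyl becoming 4-chlorophenyl. Within the data shown here, no measured step touches this ring, so the side-chain step is not carried over, and no shift beyond the scatter is expected in this assay in either direction. The expected change is a 1.1-fold lower number from compound 1 to compound 3 (0.05 log units; within the scatter) on this estimate. For compound 3 the estimated value is 5000 nM with an expected range from 1800 nM to 15000 nM around it.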

Compound 3, half-maximal inhibitory concentration: > 100000 nM
Compound 3 gave a limit, no number; the forecaster's own chance of this, stated with the estimate: 5%; middle value at least 20-fold (1.30 log units) away from the limit.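

In this assay, going by these compounds alone, the phenyl ring, which no earlier step touched, proves to be no silent position: with the side chain of compound 1 kept, 4-chlorophenyl in place of phenyl gives an at least 17-fold higher number from compound 1 to compound 3 (1.25 log units; beyond the scatter). The value of compound 3, > 100000 nM, is a limit and not a number. A single chloro, para to a large group, is therefore enough to leave the measurable range, and how far the true step extends cannot be read: the limit of > 100000 nM in this assay, at which 2 of the 3 values shown sit.

Still open, going by these compounds, is whether this step belongs to chloro itself or to any group at this carbon, which fluoro or methoxy in place of the same hydrogen would address. Also open, on these data alone, is whether another side chain, such as a longer chain ending in piperidine or a primary amine, would give a number with the phenyl ring kept.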